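A few compounds are considered here, and "the series" means these few. Any claim that something is new, unique, unknown or untested is made for them only; others in the source may bear on it.

Working notes on the series.

Three compounds have numbers in an assay on CHO-K1 cells for displacement of a labelled ligand from melanin-concentrating hormone receptor 1 (Homo sapiens), read by scintillation proximity assay, with a stated time of 2 h; a higher number here means a weaker inhibitor, a lower number a stronger inhibitor. Compound 1 `Cc1nc(NCCCNS(C)(=O)=O)nc2ccc(NC(=O)/C=C/c3ccc(OC(F)(F)F)cc3)cc12` gives 54 nM in this assay, the lowest of the three numbers. Compound 2 `COc1ccc(/C=C/C(=O)Nc2ccc3nc(N4CCC(O)(C5CC5)CC4)nc(C)c3c2)cc1` gives 116 nM in this assay, and compound 3 `CCCC1(O)CCN(c2nc(C)c3cc(NC(=O)/C=C/c4ccc(Cl)cc4)ccc3n2)CC1` gives 245 nM in this assay; both stand above compound 1 by more than the scatter, compound 3 furthest. No pair among these three differs in one place only, so the numbers of compound 2 and compound 3 show only that their combinations of groups come out weaker than that of compound 1.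

Compound 4 `Cc1nc(N2CCC(N3CCCC3=O)CC2)nc2ccc(NC(=O)/C=C/c3ccc(OC(F)(F)F)cc3)cc12` has not been measured. It keeps the trifluoromethoxy-bearing cinnamamide of compound 1 and changes the other end of the shared core: 4-(2-oxopyrrolidin-1-yl)piperidin-1-yl in place of (3-(methanesulfonamido)propyl)amino on an aromatic carbon. Going by the values given here, no measured pair isolates this change. Compound 2 and compound 3 each carry a piperidin-1-yl substituent on the core and give higher numbers than compound 1, though their aryl groups also differ. A modest move to a weaker number, a 1.9-fold higher number from compound 1 to compound 4 (0.27 log units; within the scatter), is expected, of about the size of the scatter or a little beyond it. Compound 4 is therefore estimated at 100 nM in this assay, with a range from 35 nM to 300 nM.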

Compound 4, half-maximal inhibitory concentration: 11 nM
Estimate against measurement, compound 4: 9.1-fold (0.96 log units) above; measured number below the stated range.
By their numbers in this assay, from the lowest: compound 4; then compound 1; then compound 2; then compound 3.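

Going by these compounds alone, this is the first step that isolates the group on the aromatic carbon between two ring nitrogen atoms. With the trifluoromethoxy-bearing cinnamamide held fixed, 4-(2-oxopyrrolidin-1-yl)piperidin-1-yl in place of (3-(methanesulfonamido)propyl)amino gives a 4.9-fold lower number from compound 1 to compound 4 (0.69 log units; beyond the scatter) in this assay, so this position accepts the piperidin-1-yl group and the ring alone does not bring a higher number. Nothing measured beyond these numbers offers an explanation for the step.

Going by these compounds, it remains open which part of the new group carries the step: an unsubstituted piperidin-1-yl, or a piperidine bearing a primary amine in place of the 2-oxopyrrolidin-1-yl, would separate the two rings. Also open, on these data alone, is whether the step holds with the aryl groups of compound 2 and compound 3.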